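The compounds below may be only part of what the source reports. "The series", "measured", "known", "first", "only" and "open" are said of these compounds alone.

Compound 1 `COc1ccc(CNC(=O)/C=C/c2coc3cc(OC)ccc3c2=O)cc1` in a functional assay on HeLa cells (Homo sapiens) for inhibition, read by MTT assay, with a stated time of 48 h (on this read-out higher numbers stand for weaker inhibition and lower numbers for stronger inhibition), gives > 100000 nM, which is a limit of the assay rather than a number. Compound 2 `COc1ccc(CNC(=O)/C=C/c2coc3cc(O)ccc3c2=O)cc1` in this assay gives > 100000 nM, again a limit and not a number. Going by the values given here, the one measured step, a step that the two limits leave unreadable from compound 1 to compound 2, therefore cannot be read for size; both values sit at the limit of > 100000 nM in this assay, at which 2 of the 2 values shown sit. Compound 1 thus stands only at a limit, with no number against it.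

Compound 3 `COc1ccc2c(=O)c(/C=C/C(=O)Nc3ccc(F)cc3)coc2c1` is obtained from compound 1 by 4-fluorophenyl in place of 4-methoxybenzyl on an amide-type nitrogen. Among the compounds with values here, no measured step bears on this change: the only step recorded concerns hydrogen in place of methyl on an oxygen on an aromatic ring, and even that step is unreadable. With nothing beyond two limits to go on, no step beyond the scatter in this assay can be expected in either direction, and the expected outcome is that compound 3 again returns a limit. The working estimate for compound 3 in this assay is 100000 nM, within 30000 nM to 300000 nM. The step this estimate implies, a number no higher from compound 1 to compound 3 (the limit leaves the size open), is expected to lie within the scatter.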

Compound 3, half-maximal inhibitory concentration: 9680 nM
Estimate against measurement, compound 3: 10-fold (1.01 log units) above, outside the stated range (below it).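

With 4-fluorophenyl in place of 4-methoxybenzyl on an amide-type nitrogen, this assay shows an at least 10-fold lower number from compound 1 to compound 3 (1.01 log units; beyond the scatter), a step beyond the scatter and the first readable one in the series. Compound 3 is the only compound shown that carries a number, which places a response to structure at this amide-type nitrogen, whereas the earlier step on the aromatic oxygen cannot be read. The other values shown are limits of the assay and not numbers: the limit of > 100000 nM in this assay, at which 2 of the 3 values shown sit.

The change swaps methoxy for fluorine on the aromatic ring and removes the carbon link between that ring and the nitrogen in one move, and the compounds shown do not separate these two parts or give any cause for the step. Still open, on these data alone, is whether 4-fluorobenzyl, 4-methoxyphenyl, unsubstituted phenyl or a ring bearing an amine or a carboxylic acid at this nitrogen would hold a number in this assay, and whether hydrogen in place of methyl on the aromatic oxygen would become readable with 4-fluorophenyl on the amide-type nitrogen.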